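One Added Methyl on the Amine Chain

A few compounds are considered here, and "the series" means these few. Any claim that something is new, unique, unknown or untested is made for them only; others in the source may bear on it.

Measured in a functional assay on B16-F10 cells (Mus musculus) for antiproliferative activity, read by MTT assay, with a stated time of 72 h; on this read-out lower numbers stand for stronger inhibition and higher numbers for weaker inhibition:
Compound 1 `CCCCCCCCCCCCNC[C@@H]1OC[C@H](N)[C@H]1O`: 58100 nM
Compound 2 `CCCCCCCNC[C@@H]1OC[C@H](N)[C@H]1O`: > 128000 nM (a limit)

Compound 2 has no exact number and stands at the limit of > 128000 nM in this assay, at which 1 of the 2 values shown sits. Compound 3 `CCCCCCCCNC[C@@H]1OC[C@H](N)[C@H]1O` differs from compound 2 by methyl in place of hydrogen on a saturated chain carbon, seven bonds along the chain from an amine nitrogen, which is methyl in place of hydrogen on a saturated chain carbon, seven bonds along the chain from an amine nitrogen.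

Among the measured compounds shown here, only one measured step bears on this change. With hydrogen in place of pentyl at that same place, the result was an at least 2.2-fold higher number from compound 1 to compound 2 (0.34 log units; beyond the scatter). Methyl restores only a small part of that pentyl, so a small shift toward compound 1 at 58100 nM is expected, perhaps none beyond the scatter. In numbers, the expected change is an at least 1.1-fold lower number from compound 2 to compound 3 (0.06 log units; that floor lies within the scatter). Compound 3 is estimated at 110000 nM, with an expected range of 70000 nM to 170000 nM.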

Compound 3, half-maximal inhibitory concentration: > 128000 nM
Compound 3 ended at the assay's limit (the forecaster's own chance of this, stated with the estimate: 55%); at least 1.1-fold (0.06 log units) between middle value and limit.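

In this assay, the added methyl does not bring a readable number: compound 3 sits at a limit of the assay, as compound 2 does, so the step between them cannot be read. Hydrogen in place of butyl on a saturated chain carbon, eight bonds along the chain from an amine nitrogen, still gives an at least 2.2-fold higher number from compound 1 to compound 3 (0.34 log units; beyond the scatter). Among these compounds, only compound 1 has an exact value, and the comparison stops at one edge of what the assay reports: the limit of > 128000 nM in this assay, at which 2 of the 3 values shown sit.

The compounds shown leave open where along the chain an exact number first appears, a question that a decyl chain on the shared core would address. They also leave open whether a longer chain, such as tetradecyl, would give a lower number than compound 1.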